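Moving a methyl group from compound 3 to compound 4

A few compounds are considered here, and "the series" means these few. Any claim that something is new, unique, unknown or untested is made for them only; others in the source may bear on it.

Three compounds have been measured in a functional assay on M21 cells (Homo sapiens) for antiproliferative activity, read by sulforhodamine B assay, with a stated time of 48 h (on this read-out lower numbers stand for stronger inhibition and higher numbers for weaker inhibition), so far:
Compound 1 `CCc1ccccc1NS(=O)(=O)c1ccc(N2CCNC2=O)cc1` gives 180 nM
Compound 2 `O=C1NCCN1c1ccc(S(=O)(=O)Nc2ccc(C3CCCCC3)cc2)cc1` gives > 1000 nM (a limit of the assay)
Compound 3 `Cc1cccc(NS(=O)(=O)c2ccc(N3CCNC3=O)cc2)c1` gives 69 nM

Compound 3 holds the lower of the two true numbers, and compound 1 is its nearest neighbour. Among the measured compounds shown here, compound 2 reports only a limit (> 1000 nM) and so offers no step to compare.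

Compound 4 `Cc1ccc(NS(=O)(=O)c2ccc(N3CCNC3=O)cc2)cc1` has not yet been measured. Its difference from compound 3 is 4-methylphenyl in place of 3-methylphenyl on a sulfonamide nitrogen and amounts to 4-methylphenyl in place of 3-methylphenyl on a sulfonamide nitrogen. The two compounds have the same atoms, joined differently.

For the measured compounds named here, with a 2.6-fold lower number from compound 1 to compound 3 (0.42 log units; beyond the scatter) as the only measured step at this place, a change of similar modest size is expected in this assay for compound 4, more likely towards a higher number given that compound 3 at 69 nM is already the lowest true number. The step expected is a 2.0-fold higher number from compound 3 to compound 4 (0.31 log units; beyond the scatter) as estimated here. Compound 4 is estimated at 140 nM with an expected range from 40 nM to 450 nM in this reading.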

Compound 4, half-maximal inhibitory concentration: 260 nM
Beside the measured number, compound 4's estimate is 1.9-fold (0.27 log units) below it; the measured number falls inside the stated range.
By their numbers in this assay, from the lowest: compound 3; then compounds 1 and 4 (each within the scatter of the next). At a limit, above all of these: compound 2.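

In this assay, the placement of one methyl group on the phenyl ring carried by the sulfonamide nitrogen is enough on its own to shift the read-out, with a 3.8-fold higher number from compound 3 to compound 4 (0.58 log units; beyond the scatter) and no atom gained or lost. The 4-methylphenyl and 2-ethylphenyl groups cannot be told apart here, with a 1.4-fold higher number from compound 1 to compound 4 (0.16 log units; within the scatter) within the scatter, which leaves the 3-methylphenyl group of compound 3 alone with the lowest number among the three true values. Compound 2 reports a limit and not a number, so methyl in place of cyclohexyl on an aromatic carbon can be read only as a bound, with an at least 3.8-fold lower number from compound 2 to compound 4 (0.58 log units; beyond the scatter) as its reading at that limit: the limit of > 1000 nM in this assay, at which 1 of the 4 values shown sits.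

The compounds shown do not tell whether the preference for the 3-methylphenyl group would hold for a methoxy group, a chlorine atom or a carboxylic acid in place of that methyl group. They also leave open why moving the methyl group changes the number, and whether the same order would hold with any change to the shared core.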